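The source may report more compounds than this note shows. Statements on the series, on what has been measured and on what is new or still open speak of the compounds shown alone.

Working notes on the series.

Compound 1 `Cc1cc(Nc2cc(-c3ccccc3)[nH]n2)n2nc(SCc3c(Cl)cccc3Cl)nc2n1` is measured in an ADME assay on GES1 cells (Homo sapiens) for inhibition, read by MTT assay, with a stated time of 72 h (on this read-out lower numbers stand for stronger inhibition and higher numbers for weaker inhibition), where compound 1 gives 39600 nM. Compound 2 `Cc1cc(Nc2ccn(Cc3ccc(F)cc3)n2)n2nc(SCc3ccc(Br)cc3)nc2n1`, which shares the core but carries a different arylmethyl group on the sulfur and a different substitution on the pyrazole, gives 40500 nM in this assay. Compound 1 has the smaller of the two numbers shown, but the gap to compound 2 lies within the usual scatter, so the two cannot be told apart on this read-out.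

Compound 3 `Cc1cc(Nc2cc(-c3ccccc3)[nH]n2)n2nc(SCc3ccc(C(F)(F)F)cc3)nc2n1` is not yet measured. Relative to compound 1 it differs in one place: 4-(trifluoromethyl)phenyl in place of 2,6-dichlorophenyl on a saturated chain carbon bound to a sulfur. Going by the values given here, no measured pair in the set shows the effect of such a change, so there is no step to lean on. The expectation is that the step from compound 1 to compound 3 in this assay stays within the scatter, with no clear direction: a 1.0-fold higher number from compound 1 to compound 3 (0.00 log units; within the scatter). Compound 3 is estimated at 40000 nM, within 15000 nM to 100000 nM.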

Compound 3, half-maximal inhibitory concentration: 42700 nM
Estimate against measurement, compound 3: 1.1-fold (0.03 log units) below; the range from low to high includes it.
By their numbers in this assay, from the lowest: compounds 1, 2 and 3 (each within the scatter of the next).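

The exchange at this position, on a saturated chain carbon bound to a sulfur, can now be read as a single change: 4-(trifluoromethyl)phenyl in place of 2,6-dichlorophenyl gives a 1.1-fold higher number from compound 1 to compound 3 (0.03 log units; within the scatter) in this assay. Going by these compounds alone, in this one pair, going from 2,6-dichlorobenzyl to 4-(trifluoromethyl)benzyl therefore leaves no difference that can be told apart on this read-out, a point the earlier compounds could not show, as they differ in more than one place. Nothing at hand bears on the reason for this result.

On these data alone, whether a carboxylic acid, an amine or a longer chain between the sulfur and the ring would give a step beyond the scatter remains open. Also open, as far as these compounds go, is whether the same exchange reads alike on the core of compound 2, which carries a different substitution on the pyrazole.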